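Cyclopentyl in place of tert-butyl: an expected growth inhibition

This account rests on a few compounds, and the source may have more. Where it says the series, first, only, none or still open, it means among the compounds named here.

Compound 1, `CC(C)(C)CCOc1cccc(O)c1C(=O)/C=C/c1ccc(O)cc1`: in a functional assay on NUGC-3 cells (Homo sapiens) for antiproliferative activity, read by sulforhodamine B assay (on this read-out lower numbers stand for stronger inhibition of growth and higher numbers for weaker inhibition of growth), compound 1 gives 3300 nM.
Compound 2, `CC(C)COc1cccc(O)c1C(=O)/C=C/c1ccc(O)cc1`: compound 2 gives 2980 nM.
Compound 3, `O=C(/C=C/c1ccc(O)cc1)c1c(O)cccc1OCc1ccccc1`: for compound 3 the value > 30000 nM is a limit of the assay, not a number.

Going by the values given here, only two of the three compounds carry a number. Compound 1 is one of them, and the other, compound 2, lies within the scatter of it: a 1.1-fold lower number from compound 1 to compound 2 (0.04 log units; within the scatter). The third, compound 3, reaches only the limit (the limit of > 30000 nM in this assay, at which 1 of the 3 values shown sits). The two steps that lead to it are both beyond the scatter: an at least 9.0-fold higher number from compound 1 to compound 3 (0.95 log units; beyond the scatter) and an at least 10-fold higher number from compound 2 to compound 3 (1.00 log units; beyond the scatter).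

Compound 4, `O=C(/C=C/c1ccc(O)cc1)c1c(O)cccc1OCCC1CCCC1`, has not been measured. It differs from compound 1 by cyclopentyl in place of tert-butyl on a saturated chain carbon, two bonds along the chain from an oxygen on an aromatic ring. Among the compounds with values here, of the measured steps, the one to compound 2 bears most closely on this change, since there, too, one saturated branched group replaced another and the number hardly moved. The steps to compound 3 show that a phenyl in the same place gave a large loss, but cyclopentyl is a five-membered non-aromatic ring of carbon only, not an aromatic one. The expected step is therefore a 1.0-fold lower number from compound 1 to compound 4 (0.01 log units; within the scatter), none beyond the scatter. Compound 4 is estimated at 3200 nM, with a range from 1200 nM to 9000 nM.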

Compound 4, concentration for 50% growth inhibition: 3200 nM
Estimate against measurement, compound 4: no gap at the digits printed; measured number inside the range.
By their numbers in this assay, from the lowest: compounds 2, 4 and 1 (each within the scatter of the next). At a limit, above all of these: compound 3.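

In this assay, a ring of carbon only is tolerated two bonds along the chain from the oxygen on the aromatic ring: cyclopentyl in place of tert-butyl gives a 1.0-fold lower number from compound 1 to compound 4 (0.01 log units; within the scatter), and cyclopentylmethyl in place of isopropyl gives a 1.1-fold higher number from compound 2 to compound 4 (0.03 log units; within the scatter). Going by these compounds alone, until this result, the only ring in this chain was the phenyl of compound 3, whose value is a limit of the assay and not a number: the limit of > 30000 nM in this assay, at which 1 of the 4 values shown sits. The step of an at least 9.3-fold lower number from compound 3 to compound 4 (0.97 log units; beyond the scatter) now separates that compound from the rest, so among the four compounds a ring in this chain does not by itself go with the loss, and compound 3 alone stands apart from compounds 1, 2 and 4.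

Compounds 3 and 4 differ both in the kind of ring and in where it sits on the chain, so the compounds shown do not tell which of the two matters; a 2-phenylethyl group or a cyclopentyl on the carbon bound to the oxygen would separate them. Also open is how this place responds to a chain carrying an amine, a hydroxyl or a carboxylic acid, since every group shown here is built of carbon only.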